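A Heteroaryl Amide in Place of the Dichlorophenyl Group

The source may hold more compounds than are shown below. What is called first, only, known or untested is meant among the compounds shown, and "the series" means these compounds.

Compounds measured in an assay on isolated protein for inhibition of phosphodiesterase 4A (Sus scrofa); a higher number here means a weaker inhibitor, a lower number a stronger inhibitor:
compound 1 `COc1ccc(C(=O)Nc2cccc(Cl)c2Cl)cc1OC1CCCC1`, > 200000 nM
compound 2 `COc1ccc(C(=O)Nc2ccccc2Cl)cc1OC(C)=O`, 70000 nM
compound 3 `COc1ccc(C(=O)Nc2c(Cl)c(F)nc(F)c2Cl)cc1OC1CCCC1`, 20 nM

The reading for compound 1 is a limit of the assay and not a number, as the limit of > 200000 nM in this assay, at which 1 of the 3 values shown sits, shows. Compound 2 gives 70000 nM in this assay, a weak result with a number attached. Among the measured compounds shown here, compound 3, which carries a halogenated pyridyl ring on the amide nitrogen, gives 20 nM, by far the strongest inhibition of the three; no single-point step links it to compound 1, so only the two values can be set side by side.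

Compound 4 `COc1ccc(C(=O)Nc2c(C)nsc2Br)cc1OC1CCCC1` has not yet been measured. It differs from compound 1 in one place: 5-bromo-3-methyl-1,2-thiazol-4-yl in place of 2,3-dichlorophenyl on an amide-type nitrogen. Compound 3 at 20 nM is the sole case of a heteroaryl amide among the measured compounds. Compound 1, for its part, stands at a limit of the assay rather than at a number. On that basis the step of an at least 400-fold lower number from compound 1 to compound 4 (2.60 log units; beyond the scatter) is expected to be a large gain in this assay, far beyond the usual scatter. Compound 4 is therefore estimated at 500 nM, with a plausible range from 40 nM to 10000 nM.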

Compound 4, half-maximal inhibitory concentration: 500 nM
Beside the measured number, compound 4's estimate shows no gap at the digits printed, within the range that was stated.
By their numbers in this assay, from the lowest: compound 3; then compound 4; then compound 2. At a limit, above all of these: compound 1.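

In this assay, among the compounds shown here, 5-bromo-3-methyl-1,2-thiazol-4-yl in place of 2,3-dichlorophenyl on the amide-type nitrogen gives an at least 400-fold lower number from compound 1 to compound 4 (2.60 log units; beyond the scatter), the first step in this set between measured compounds that differ in one place. The gain at this position is thus not confined to the halogenated pyridyl ring of compound 3, as a five-membered aromatic ring with 2 hetero atoms also gives a large step. The true size of the step stays unknown, as compound 1 stands at a limit of the assay and not at a number: the limit of > 200000 nM in this assay, at which 1 of the 4 values shown sits.

Going by these compounds, how much of the step belongs to the ring itself and how much to its bromine or its methyl remains open. So does whether an amine or a carboxylic acid in place of the bromine would keep this level of inhibition.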